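The source may report more compounds than this note shows. Statements on the series, on what has been measured and on what is new or still open speak of the compounds shown alone.

Among the compounds with values here, the three compounds measured so far share one core and differ only in the aryl group on the carbonyl carbon. Compound 1 `COc1cc(-c2cc(/C=C/C(=O)c3ccc(N)cc3)[nH]n2)cc(OC)c1OC` carries a 4-aminophenyl there, and in a functional assay on RXF 393 cells (Homo sapiens) for inhibition, read by sulforhodamine B assay, with a stated time of 48 h (on this read-out higher numbers stand for lower toxicity in this test and lower numbers for higher toxicity in this test), compound 1 gives 7790 nM. Compound 2 `COc1ccc(C(=O)/C=C/c2cc(-c3cc(OC)c(OC)c(OC)c3)n[nH]2)cc1OC` carries a 3,4-dimethoxyphenyl, and in this assay compound 2 gives 5230 nM, the smallest of the three numbers, although its gap to compound 1 is within the scatter. Compound 3 `COc1cc(-c2cc(/C=C/C(=O)c3ccc(F)c(F)c3)[nH]n2)cc(OC)c1OC` carries a 3,4-difluorophenyl, and in this assay compound 3 gives 54100 nM. The two steps that touch compound 2 are a 1.5-fold lower number from compound 1 to compound 2 (0.17 log units; within the scatter) and a 10-fold higher number from compound 2 to compound 3 (1.01 log units; beyond the scatter). Compound 4 `COc1cc(C(=O)/C=C/c2cc(-c3cc(OC)c(OC)c(OC)c3)n[nH]2)cc(OC)c1OC` differs from compound 2 by methoxy in place of hydrogen on an aromatic carbon. Within the data shown here, no measured step adds or removes a single methoxy on this ring; the only step that swaps one oxygen-bearing aryl for another is the small one from compound 1 to compound 2. A small step in this assay is therefore expected, a 1.0-fold lower number from compound 2 to compound 4 (0.02 log units; within the scatter). Compound 4 is estimated at 5000 nM, with a range from 1500 nM to 16000 nM.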

Compound 4, concentration lethal to 50% of the cells: 5680 nM
For compound 4 the middle estimate is 1.1-fold (0.06 log units) below the measured one, and the stated range covers the measured number.
By their numbers in this assay, from the lowest: compounds 2, 4 and 1 (each within the scatter of the next); then compound 3.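

Until now, every step swapped the whole aryl group on the carbonyl carbon, so nothing showed what one added group does on that ring. Here a methoxy replaces hydrogen on an aromatic carbon, ortho to a methoxy group and meta to a large group, and in this assay the result is a 1.1-fold higher number from compound 2 to compound 4 (0.04 log units; within the scatter) and so no shift beyond the scatter. This ring therefore accepts one more methoxy at this carbon with compound 4 staying level with compound 2 in this test.

On these data alone, whether a hydroxy group, an amine or a longer chain such as ethoxy on the same carbon would also leave the number in place remains open. Nothing available here explains why the added methoxy makes no measurable difference.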